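Carboxy to Carbamoyl: Expecting Little Change

A few compounds are considered here, and "the series" means these few. Any claim that something is new, unique, unknown or untested is made for them only; others in the source may bear on it.

In a functional assay on MCF7 cells (Homo sapiens) for cytotoxicity, read by sulforhodamine B assay, with a stated time of 48 h, in the presence of a further agent that is not named here (a lower number here means a stronger inhibitor of growth, a higher number a weaker inhibitor of growth), compound 2 `Cc1nn(-c2ccccc2)c(Sc2ccc(-c3nc4cc(C(=O)O)ccc4[nH]3)cc2)c1/C=N/NC(N)=O` gives 60 nM, and compound 1 `Cc1nn(-c2ccccc2)c(Sc2ccc(-c3nc4cc([N+](=O)[O-])ccc4[nH]3)cc2)c1/C=N/NC(N)=O` gives 100 nM. These two numbers stand level, and compound 2 holds the best measured position alongside compound 1. Among the measured compounds shown here, the one measured step is carboxy in place of nitro on an aromatic carbon, a 1.7-fold lower number from compound 1 to compound 2 (0.22 log units; within the scatter). Compound 3 `Cc1nn(-c2ccccc2)c(Oc2ccc(-c3nc4cc(C(N)=O)ccc4[nH]3)cc2)c1/C=N/NC(N)=O`, which also carries a carbamoyl group, gives only a limit of the assay, > 100000 nM, so the upper end of the range is set wide. Compound 4 `Cc1nn(-c2ccccc2)c(Sc2ccc(-c3nc4cc(C(N)=O)ccc4[nH]3)cc2)c1/C=N/NC(N)=O` differs from compound 2 by amino in place of hydroxy on a carbonyl carbon. In this assay no change beyond the scatter is expected, and the estimated step is a 1.5-fold higher number from compound 2 to compound 4 (0.18 log units; within the scatter). For compound 4 the estimated value is 90 nM, with an expected range of 25 nM to 600 nM.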

Compound 4, concentration for 50% growth inhibition: > 100000 nM
Compound 4: only a limit was reported; the forecaster's own chance of this, stated with the estimate: 8%; middle value at least 1100-fold (3.04 log units) away from the limit.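

At this position carboxy and carbamoyl cannot be treated as near-equivalents: in this assay the change is an at least 1600-fold higher number from compound 2 to compound 4 (3.22 log units; beyond the scatter), and the step from the nitro compound is an at least 1000-fold higher number from compound 1 to compound 4 (3.00 log units; beyond the scatter). Compound 4 gives > 100000 nM, which is a limit of the assay and not a number. Both compounds shown with carbamoyl, compound 3 and compound 4, sit at that limit: the limit of > 100000 nM in this assay, at which 2 of the 4 values shown sit.

The compounds shown leave open why carbamoyl differs so sharply from carboxy and nitro. They also leave open whether a methyl ester or a hydroxymethyl group here would behave like carboxy or like carbamoyl.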